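The source may hold more compounds than are shown below. What is called first, only, known or untested is meant among the compounds shown, and "the series" means these compounds.

Going by the values given here, compound 2 `Nc1ncnc2c1nc(NCc1cccc3ccccc13)n2[C@@H]1O[C@H](CO)[C@@H](O)[C@H]1O` is the one member of this small set with a measured number: in an assay on COS-7 cells for inhibition of sodium/nucleoside cotransporter 2 (Homo sapiens), read by scintillation counting, in the presence of a further agent that is not named here (on this read-out higher numbers stand for weaker inhibition and lower numbers for stronger inhibition), compound 2 gives 5700 nM. Compound 1 `COc1ccccc1CNc1nc2c(N)ncnc2n1[C@@H]1O[C@H](CO)[C@@H](O)[C@H]1O` reaches only a limit in this assay, namely > 100000 nM, the limit described as the limit of > 100000 nM in this assay, at which 1 of the 2 values shown sits. Among the compounds with values here, the single comparable step runs an at least 17-fold lower number from compound 1 to compound 2 (1.24 log units; beyond the scatter), so the group on the saturated chain carbon bound to the ring nitrogen clearly matters. Compound 3 `Nc1ncnc2c1nc(NCCCc1ccccc1)n2[C@@H]1O[C@H](CO)[C@@H](O)[C@H]1O` changes that same group again: phenethyl in place of naphthalen-1-yl on a saturated chain carbon bound to a nitrogen on an aromatic ring. Within the data shown here, that measured step, which was large, is the only guide, and it shows that swapping this group can shift the read-out strongly; a phenethyl chain is as new here as the naphthalen-1-yl was, so the direction is uncertain, but with the naphthalen-1-yl gone a move back towards weaker inhibition seems more likely. Compound 3 is therefore expected to show a 5.3-fold higher number from compound 2 to compound 3 (0.72 log units; beyond the scatter), giving an estimated 30000 nM with a range from 7000 nM to 100000 nM.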

Compound 3, half-maximal inhibitory concentration: 536000 nM
Estimate against measurement, compound 3: 18-fold (1.25 log units) below, outside the stated range (above it).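

In this assay, phenethyl in place of naphthalen-1-yl on a saturated chain carbon bound to a nitrogen on an aromatic ring gives a 94-fold higher number from compound 2 to compound 3 (1.97 log units; beyond the scatter). This shows that the gain seen with naphthalen-1-yl does not extend to every all-carbon aromatic group at this place: phenethyl, with one six-membered aromatic ring instead of two, loses nearly all of that inhibition. Compound 1 gives only a limit, and the step from it to compound 3 cannot be read because of that limit: the limit of > 100000 nM in this assay, at which 1 of the 3 values shown sits.

The compounds shown cannot separate the effect of the second aromatic ring from that of the chain in phenethyl, since both differ in this one change. A naphthalen-2-yl group, or a longer chain ending in naphthalen-1-yl, would help to tell these apart.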